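Sulfonamide series: metabolic half-life, compound 2 to compound 3

The compounds below may be only part of what the source reports. "The series", "measured", "known", "first", "only" and "open" are said of these compounds alone.

Measured compounds and their values:
- compound 1, `CC(C)CC1n2cncc2CN(Cc2ccc(OC(F)(F)F)cc2)S1(=O)=O`: 0.117 h
- compound 2, `C[C@@H](c1ccc(Cl)cc1)N1Cc2cncn2C(CC2(C)COC2)S1(=O)=O`: 1.27 h

In an in vitro ADME assay on microsomes from liver (Homo sapiens) for metabolic stability (a lower number here means that the compound disappears faster, a higher number that the compound lasts longer), compound 2 stands highest of the two numbers measured; its nearest neighbour is compound 1, and the gap between them lies beyond the scatter. Going by the values given here, compound 1 carries an isobutyl chain and a trifluoromethoxybenzyl group, while compound 2 carries the branched chain with the oxetane and a chlorophenylethyl group, so the two measured compounds differ in more than one place and no single step between them can be read.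

Compound 3, `CC(C)OCC1n2cncc2CN([C@@H](C)c2ccc(Cl)cc2)S1(=O)=O`, has not yet been measured in this assay. Relative to compound 2 the change is isopropoxy in place of 3-methyloxetan-3-yl on a saturated chain carbon bound to a saturated ring carbon. Among the compounds with values here, no measured pair shows this change, so the size of the step rests on judgement alone. The step from compound 2 is expected to be a moderate decrease, a 2.1-fold lower number from compound 2 to compound 3 (0.33 log units; beyond the scatter), possibly no larger than the scatter. Compound 3 is thus expected to give about 0.6 h, with a likely range from 0.2 h to 1.8 h.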

Compound 3, half-life: 0.0833 h
Compound 3: the middle estimate sits 7.2-fold (0.86 log units) above what was measured; the whole stated range lies above it.
By their numbers in this assay, from the lowest: compounds 3 and 1 (each within the scatter of the next); then compound 2.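

Isopropoxy in place of 3-methyloxetan-3-yl on a saturated chain carbon bound to a saturated ring carbon gives a 15-fold lower number from compound 2 to compound 3 (1.18 log units; beyond the scatter) in this assay; this is the only single-place step shown, and it establishes that a change at this position alone can produce a large step in half-life. The two groups have the same counts of hydrogen-bond donors and acceptors and no net charge, so these counts do not separate compound 2 from compound 3. No measurement in hand accounts for the size of the step.

Steps involving compound 1 cannot be read, as it differs from both other compounds in more than one place, and whether the same step would appear with its trifluoromethoxybenzyl group stays open. On these data alone, it also stays open whether the step follows the loss of the oxetane ring or the change in the place of the oxygen, which an ethoxy group or a cyclobutyl ring at this position would help to separate.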